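From hydroxy to methoxy at the assay limit

The compounds below may be only part of what the source reports. "The series", "measured", "known", "first", "only" and "open" are said of these compounds alone.

Compound 1 `O=C1OC(Cc2nc(-c3ccc(-c4ccccc4)cc3)no2)c2ccccc21`: > 10000 nM
Compound 2 `COc1cc(OC)c2c(c1)C(C(O)c1ccc(O)cc1)OC2=O`: > 10000 nM

Both entries come from a functional assay on RAW264.7 cells (Mus musculus) for inhibition, read by Griess assay, with stated times of 1 h and 24 h; a higher number here means a weaker inhibitor, a lower number a stronger inhibitor. In this assay compound 2 gives > 10000 nM, which is a limit of the assay and not a number. The entry for compound 1 is a limit too, and the two entries together read: the limit of > 10000 nM in this assay, at which 2 of the 2 values shown sit. Compound 2 therefore has no exact position on the scale.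

Compound 3 `COc1ccc(C(O)C2OC(=O)c3c(OC)cc(OC)cc32)cc1` has not yet been measured. It differs from compound 2 in one place: methyl in place of hydrogen on an oxygen on an aromatic ring. Put another way, the 4-hydroxyphenyl of compound 2 becomes 4-methoxyphenyl in compound 3.

Going by the values given here, no measured pair of compounds differs in just one place, so the data do not show how far such a change can move a result in this assay. The expectation rests on compound 2, with its limit of > 10000 nM, and on the change being confined to one place. The expected step, a step that the limit leaves unreadable from compound 2 to compound 3, is none beyond the scatter, in either direction. Compound 3 is most likely to be reported as a limit again. For compound 3 the estimated value is 15000 nM, with an expected range of 6000 nM to 40000 nM.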

Compound 3, half-maximal inhibitory concentration: > 10000 nM
Compound 3 was reported as a limit; the forecaster's own chance of this, stated with the estimate: 75%; the middle value lies beyond the limit too.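

In this assay compound 3 gives > 10000 nM, which is a limit of the assay and not a number. No step from compound 2 to compound 3 can be read, as all the entries share one reading: the limit of > 10000 nM in this assay, at which 3 of the 3 values shown sit.

Still open, on these data alone, is how strong an inhibitor each compound is, and whether changing hydroxy to methoxy moves the result at all.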